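The source may hold more compounds than are shown below. What is called first, only, known or untested is meant among the compounds shown, and "the series" means these compounds.

Measured so far:
Compound 1, `CCCCNc1nc(C(F)(F)F)ccc1CNC(=O)C(C)c1ccc(NS(C)(=O)=O)c(F)c1`: 293 nM
Compound 2, `CC(C(=O)NCc1ccc(C(F)(F)F)nc1N(C)C)c1ccc(NS(C)(=O)=O)c(F)c1`: 2390 nM

In a functional assay on CHO-K1 cells for antagonist activity at transient receptor potential cation channel subfamily V member 1 (Homo sapiens), read by FLIPR (a lower number here means a stronger inhibitor, a higher number a weaker inhibitor), compound 2 gives the higher of the two numbers, that is, it is the weaker inhibitor of the pair. Among the measured compounds shown here, the only measured step is an 8.2-fold higher number from compound 1 to compound 2 (0.91 log units; beyond the scatter), which separates it from compound 1.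

Compound 3, `CC(C(=O)NCc1ccc(C(F)(F)F)nc1N(C)c1ccccc1)c1ccc(NS(C)(=O)=O)c(F)c1`, differs from compound 2 in one place: phenyl in place of methyl on a nitrogen on an aromatic ring, so that dimethylamino becomes methyl(phenyl)amino. For the measured compounds named here, the one step that touches this same nitrogen is an 8.2-fold higher number from compound 1 to compound 2 (0.91 log units; beyond the scatter), where the group with more heavy atoms, butylamino, went with the lower number. Phenyl likewise brings more heavy atoms than methyl, though it is a ring rather than a chain, so the guide is loose. A modest step toward a lower number is therefore expected, a 3.0-fold lower number from compound 2 to compound 3 (0.48 log units; beyond the scatter). For compound 3 the estimate in this assay is 800 nM, with a range from 150 nM to 4000 nM.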

Compound 3, half-maximal inhibitory concentration: 57.4 nM
Estimate against measurement, compound 3: 14-fold (1.14 log units) above, outside the stated range (below it).
By their numbers in this assay, from the lowest: compound 3; then compound 1; then compound 2.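

In this assay, this nitrogen on the aromatic ring takes a phenyl group and gives far stronger inhibition, with a 42-fold lower number from compound 2 to compound 3 (1.62 log units; beyond the scatter) for phenyl in place of methyl. The earlier pair compared only butylamino and dimethylamino, both without a ring, whereas methyl(phenyl)amino also beats butylamino, with a 5.1-fold lower number from compound 1 to compound 3 (0.71 log units; beyond the scatter) in this series, making compound 3 the strongest inhibitor of the three. No measurement shown explains why this change has so large an effect.

The compounds shown leave open whether an aromatic ring is needed here, or whether a saturated ring such as cyclohexyl would serve as well. They also leave open whether the remaining methyl on this nitrogen matters, which a hydrogen in its place would test, and how a fluorine or methoxy group on the phenyl ring would alter the result.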